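Furanyl for trimethoxyphenyl on the longer-linker core

A few compounds are considered here, and "the series" means these few. Any claim that something is new, unique, unknown or untested is made for them only; others in the source may bear on it.

Measured so far:
compound 1 `COc1cc(/C=C/C(=O)/C=C/c2cc(OC)c(OC)c(OC)c2)ccc1OCc1cn(CCOc2cc(=O)oc3ccccc23)nn1` — 86%
compound 2 `COc1cc(/C=C/C(=O)/C=C/c2ccco2)ccc1OCc1cn(CCOc2cc(=O)oc3ccccc23)nn1` — 68%
compound 3 `COc1cc(/C=C/C(=O)/C=C/c2cc(OC)c(OC)c(OC)c2)ccc1OCc1cn(CCCCCOc2cc(=O)oc3ccccc23)nn1` — 51%

In a functional assay on COLO 205 cells (Homo sapiens) for inhibition, read by sulforhodamine B assay, with a stated time of 48 h, tested at 50 uM (a higher number here means more inhibition of growth at the concentration tested, a lower number less inhibition of growth), compound 1 gives 86%. Replacing one end of the dienone, (furan-2-yl in place of 3,4,5-trimethoxyphenyl on a double-bonded chain carbon bound to a double-bonded chain carbon), gives compound 2 at 68%; the step is a number 18 percentage points lower from compound 1 to compound 2 (beyond the scatter). Compound 3 carries the longer linker to the coumarin and gives 51%, the lowest of the three; the difference between the two cores is not broken down here.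

Compound 4 `COc1cc(/C=C/C(=O)/C=C/c2ccco2)ccc1OCc1cn(CCCCCOc2cc(=O)oc3ccccc23)nn1` is not yet measured. It stands to compound 3 as compound 2 stands to compound 1: furan-2-yl in place of 3,4,5-trimethoxyphenyl on a double-bonded chain carbon bound to a double-bonded chain carbon, the same change at the same place. The expected step in this assay from compound 3 to compound 4 is a number 18 percentage points lower from compound 3 to compound 4 (beyond the scatter), taken from the step of a number 18 percentage points lower from compound 1 to compound 2 (beyond the scatter) on the other core. Compound 4 is therefore estimated at 33%, with a range of 18% to 48% expected.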

Compound 4, percent growth inhibition at one concentration: 33%
Beside the measured number, compound 4's estimate shows no gap at the digits printed; low and high end bracket the measured number.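

In this assay, furan-2-yl in place of 3,4,5-trimethoxyphenyl on the longer-linker core gives a number 18 percentage points lower from compound 3 to compound 4 (beyond the scatter). The change carries over between the two cores with its size unaltered: the same change on two cores in this assay, a number 18 percentage points lower (beyond the scatter) from compound 1 to compound 2 and a number 18 percentage points lower (beyond the scatter) from compound 3 to compound 4, 0 percentage points apart, within the scatter of two such steps. Among these compounds, this rests on only two matched pairs, tested at a single concentration in one cell line, so it supports transfer between these two cores alone and gives no reason why the step holds.

Still open, as far as these compounds go, is whether the step holds with other groups at this place, such as thiophen-2-yl or a phenyl with a single methoxy, or with a linker chain of another length. Also open, from the compounds shown here alone, is whether it holds across a range of concentrations or in other cell lines.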